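A few compounds are considered here, and "the series" means these few. Any claim that something is new, unique, unknown or untested is made for them only; others in the source may bear on it.

Measured so far in an ADME assay on NIH3T3 cells (Mus musculus) for cytotoxicity, read by XTT assay, with a stated time of 24 h; a higher number here means a weaker inhibitor, a lower number a stronger inhibitor:
compound 1, `Cc1ccc(-c2csc(N3N=C(c4ccc(C)s4)CC3c3ccc(F)cc3)n2)cc1`, > 500 ug/mL, a limit of the assay.
compound 2, `Cc1ccc(C2=NN(c3nc(-c4ccc(F)cc4)cs3)C(c3ccc(F)cc3)C2)s1`, > 500 ug/mL, also a limit.
compound 3, `Cc1ccc(C2=NN(c3nc(-c4ccc(S(C)(=O)=O)cc4)cs3)C(c3ccc(F)cc3)C2)s1`, 374 ug/mL.

For the measured compounds named here, compound 3 is thus the only one with a plain number; the other two values are limits, both sitting at the limit of > 500 ug/mL in this assay, at which 2 of the 3 values shown sit. Compound 4, `Cc1ccc(C2=NN(c3nc(-c4ccc(C(F)(F)F)cc4)cs3)C(c3ccc(F)cc3)C2)s1`, differs from compound 3 by trifluoromethyl in place of methylsulfonyl on an aromatic carbon. Going by the values given here, two measured steps bear on this position: an at least 1.3-fold lower number from compound 1 to compound 3 (0.12 log units; that floor lies within the scatter) and an at least 1.3-fold lower number from compound 2 to compound 3 (0.12 log units; that floor lies within the scatter). Both are floors that lie within the scatter, so the methylsulfonyl group has not clearly changed the read-out. Moving away from it again is therefore expected to give a step of a 1.2-fold higher number from compound 3 to compound 4 (0.08 log units; within the scatter), within the scatter. Compound 4 is expected to give 450 ug/mL, with a range from 280 ug/mL to 700 ug/mL.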

Compound 4, half-maximal inhibitory concentration: > 500 ug/mL
Compound 4 gave a limit, no number (the forecaster's own chance of this, stated with the estimate: 45%); at least 1.1-fold (0.04 log units) between middle value and limit.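

In this assay, for the compounds shown here, compound 4 gives only a limit, so trifluoromethyl at this position joins methyl and fluoro at that limit, and methylsulfonyl remains the only group here with a plain number. The change reads as an at least 1.3-fold higher number from compound 3 to compound 4 (0.12 log units; that floor lies within the scatter), so methylsulfonyl is still not clearly set apart from the other groups. The steps from compound 1 and compound 2 to compound 4 cannot be read, and the set now crowds at one end: the limit of > 500 ug/mL in this assay, at which 3 of the 4 values shown sit.

On these data alone, the order among methyl, fluoro and trifluoromethyl stays open. As far as these compounds go, whether an amine or a carboxylic acid in this place would give a plain number, and a clearly lower one, is also open.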